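The source may hold more compounds than are shown below. What is called first, only, known or untested is meant among the compounds shown, and "the series" means these compounds.

Compound 1 `O=C(CCc1cccc2c1B(O)OC2)Nc1ccc(F)cc1` and compound 2 `C#Cc1cccc(NC(=O)CCc2cccc3c2B(O)OC3)c1` share the same core and differ only in the group attached to the aromatic ring of the amide. In a functional assay on SK-OV-3 cells (Homo sapiens) for antiproliferative activity, read by MTT assay, with a stated time of 72 h (a lower number here means a stronger inhibitor, a higher number a weaker inhibitor), compound 1 gives 720 nM. In this assay compound 2 gives 980 nM, and the gap between these two numbers lies within the usual scatter, so the two compounds cannot be told apart on this evidence. Compound 3 `CSc1ccc(-c2cccc(NC(=O)CCc3cccc4c3B(O)OC4)c2)cc1` has not yet been measured. It differs from compound 2 in a single place: 4-(methylsulfanyl)phenyl in place of ethynyl on an aromatic carbon. Within the data shown here, no measured pair of compounds shows what a change of this kind does, and the two numbers so far give no guidance on a group of this size. The expected step is therefore a 1.0-fold higher number from compound 2 to compound 3 (0.01 log units; within the scatter), which amounts to no change beyond the scatter in either direction. Compound 3 is estimated at 1000 nM, within a range from 400 nM to 2500 nM.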

Compound 3, half-maximal inhibitory concentration: 140 nM
For compound 3 the middle estimate is 7.1-fold (0.85 log units) above the measured one, and the stated range ends above it.
By their numbers in this assay, from the lowest: compound 3; then compounds 1 and 2 (each within the scatter of the next).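

In this assay the swap of ethynyl for 4-(methylsulfanyl)phenyl on this aromatic carbon gives a 7.0-fold lower number from compound 2 to compound 3 (0.85 log units; beyond the scatter) and so shows that this position can take a far larger group, with 8 heavy atoms in place of 2, and still give a lower number. This is the first change in the series shown whose step is clearly beyond the scatter, so the group at this position can move the result. Nothing measured here explains why the number falls.

The compounds shown leave open whether the new aromatic ring alone is enough or whether the methylsulfanyl group on it is also needed, a question that a plain phenyl at this position would address. They also leave open how an amine or a carboxylic acid in place of that methylsulfanyl group would read in this assay on this core.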